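Removing the ethoxy group from compound 2

A few compounds are considered here, and "the series" means these few. Any claim that something is new, unique, unknown or untested is made for them only; others in the source may bear on it.

Measured so far in a functional assay on HeLa cells (Homo sapiens) for inhibition, read by sulforhodamine B assay; on this read-out lower numbers stand for stronger inhibition and higher numbers for weaker inhibition:
compound 1 `O=C1C=C(NC2CCCC2)C(=O)c2c1nc1n2[C@H]2OC[C@@H](O)[C@H]2OC1` gives > 16000 nM
compound 2 `CCOc1ccccc1NC1=CC(=O)c2nc3n(c2C1=O)[C@H]1OC[C@@H](O)[C@H]1OC3` gives 6040 nM

The entry for compound 1 is a limit, not a number. Within the data shown here, compound 2, at 6040 nM, therefore holds the only numerical value so far.

Compound 3 `O=C1C=C(Nc2ccccc2)C(=O)c2c1nc1n2[C@H]2OC[C@@H](O)[C@H]2OC1` is the next compound in this assay. It differs from compound 2 as follows: hydrogen in place of ethoxy on an aromatic carbon. This is hydrogen in place of ethoxy on an aromatic carbon, ortho to a large group, so 2-ethoxyphenyl becomes phenyl.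

Among the measured compounds shown here, only one measured step bears on this change, and only indirectly: an at least 2.6-fold lower number from compound 1 to compound 2 (0.42 log units; beyond the scatter). That step placed 2-ethoxyphenyl where cyclopentyl had stood on an amine nitrogen. For the measured compounds named here, compound 3 retains the phenyl but lacks the ethoxy, and no measured step isolates the ethoxy alone. The expected result is a 1.3-fold higher number from compound 2 to compound 3 (0.12 log units; within the scatter), which means no clear move beyond the scatter, although a drift to higher numbers would not be surprising. For compound 3 the estimated value is 8000 nM, with an expected range from 3000 nM to 20000 nM.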

Compound 3, half-maximal inhibitory concentration: 5620 nM
Beside the measured number, compound 3's estimate is 1.4-fold (0.15 log units) above it; the range from low to high includes it.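

In this assay, hydrogen in place of ethoxy on an aromatic carbon, ortho to a large group, gives a 1.1-fold lower number from compound 2 to compound 3 (0.03 log units; within the scatter), so this assay does not separate 2-ethoxyphenyl from phenyl. The earlier step could not show which part of the 2-ethoxyphenyl group went with the change, but the plain phenyl group, set in place of cyclopentyl on the amine nitrogen, gives an at least 2.8-fold lower number from compound 1 to compound 3 (0.45 log units; beyond the scatter), so the ethoxy group is not needed for a step beyond the scatter. The entry for compound 1 is a limit and not a number, so the full size of that step stays unknown: the limit of > 16000 nM in this assay, at which 1 of the 3 values shown sits.

Still open, from the compounds shown here alone, is whether the flat result at this place is particular to ethoxy, or whether a methoxy, an amine, a carboxylic acid or a longer chain ortho to the same large group would also stay within the scatter of phenyl. Going by these compounds, it is equally open whether the step from cyclopentyl needs a six-membered aromatic ring of carbon only, or whether a pyridyl or benzyl group on the amine nitrogen would give a similar result.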